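The compounds below may be only part of what the source reports. "The series", "measured", "known", "first", "only" and "open" are said of these compounds alone.

Measured compounds in a functional assay on A375P cells (Homo sapiens) for antiproliferative activity, read by MTT assay, with a stated time of 24 h; a higher number here means a weaker inhibitor, a lower number a stronger inhibitor:
- compound 1 `O=C(Nc1ccc(-n2ccc3c(NC(=O)c4ccccc4)ncnc32)cc1)c1ccc(Cl)c(Cl)c1` gives 2000 nM
- compound 2 `O=C(Nc1ccc(-n2ccc3c(NC(=O)c4ccccc4)ncnc32)cc1)Nc1cc(C(F)(F)F)cc(C(F)(F)F)c1` gives 9800 nM
- compound 3 `O=C(Nc1ccc(-n2ccc3c(NC(=O)c4ccccc4)ncnc32)cc1)c1cc(C(F)(F)F)cc(C(F)(F)F)c1` gives 2000 nM

Compound 1 stands level with compound 3 at the digits shown, within the scatter of this assay, and the two together carry the lowest numbers of the three. Compound 2 is the furthest from compound 1, with a number that is higher and beyond the scatter.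

Compound 4 `O=C(Nc1ccc(-n2ccc3c(NC(=O)c4ccccc4)ncnc32)cc1)Nc1ccc(Cl)c(Cl)c1` is not yet measured. It differs from compound 1 in one place: (3,4-dichlorophenyl)amino in place of 3,4-dichlorophenyl on a carbonyl carbon. Among the compounds with values here, compound 2 and compound 3 hold the same aryl group, and of the two the one whose value is the higher, compound 2, is the one with the amino link on the carbonyl carbon. Whether the same holds for the dichlorophenyl pair is not known from any measured pair, so the direction of the step in this assay is taken from the values of compound 2 and compound 3 only.

On that basis compound 4 is expected to give a higher number than compound 1, a step of a 3.0-fold higher number from compound 1 to compound 4 (0.48 log units; beyond the scatter). The estimate for compound 4 is 6000 nM, with a range from 2500 nM to 15000 nM.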

Compound 4, half-maximal inhibitory concentration: 4000 nM
Estimate against measurement, compound 4: 1.5-fold (0.18 log units) above; measured number inside the range.
By their numbers in this assay, from the lowest: compounds 1, 3 and 4 (each within the scatter of the next); then compound 2.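

In this assay, the first pair differing only by (3,4-dichlorophenyl)amino in place of 3,4-dichlorophenyl on a carbonyl carbon gives a 2.0-fold higher number from compound 1 to compound 4 (0.30 log units; within the scatter), so this aryl group shows no separation between the two links. The aryl group shared by compound 3 and compound 2 reads differently: compound 3 gives 2000 nM and compound 2, with the amino link, gives 9800 nM, so across these two pairs the amino link does not carry a single size of effect, and its outcome at this place depends on the aryl group attached. No measurement at hand explains this difference between the two aryl groups.

Still open, on these data alone, is whether a methylene or an oxygen in place of the amino link on the carbonyl carbon would read like either link, and whether the two pairs are the ends of a wider range of aryl groups. A 4-chlorophenyl or a pyridyl group, each carried with both links, would show whether compound 2 or the pair of compound 1 and compound 4 is the more typical case.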